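Swapping an Ether Chain for a Phenyl Ring

The compounds below may be only part of what the source reports. "The series", "measured", "known", "first", "only" and "open" are said of these compounds alone.

Compound 1, `C=CC(=O)Nc1cccc(Nc2nc(Cl)nc(Nc3ccc(Oc4ccccc4)cc3)n2)c1`, gives 15700 nM in a functional assay on Raji cells (Homo sapiens) for antiproliferative activity, read by CCK-8 assay, with a stated time of 24 h; on this read-out lower numbers stand for stronger inhibition and higher numbers for weaker inhibition.
Compound 2, `C=CC(=O)Nc1cccc(Nc2nc(N)nc(Nc3ccc(OCCOC)cc3)n2)c1`, gives 18300 nM in this assay.

Both numbers are high, so neither compound inhibits the growth of these cells strongly. Compound 2 holds the higher of the two numbers, yet compound 1 sits so close to it that the difference falls inside the usual scatter, and no order between them can be claimed.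

Compound 3, `C=CC(=O)Nc1cccc(Nc2nc(N)nc(Nc3ccc(Oc4ccccc4)cc3)n2)c1`, has not been measured. It differs from compound 2 in one place: phenyl in place of 2-methoxyethyl on an oxygen on an aromatic ring. Within the data shown here, no pair of measured compounds isolates this particular change, so nothing in the data shows directly how much it matters. Among the measured compounds shown here, the only guide is that the two measured compounds land within the scatter of each other, and that both are weak.

On that basis the expected step of a 1.1-fold lower number from compound 2 to compound 3 (0.06 log units; within the scatter) is no larger than the scatter, in no firm direction. Compound 3 is therefore estimated at about 16000 nM, with a likely range from 5000 nM to 50000 nM.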

Compound 3, half-maximal inhibitory concentration: 8320 nM
Beside the measured number, compound 3's estimate is 1.9-fold (0.28 log units) above it, and the stated range covers the measured number.
By their numbers in this assay, from the lowest: compounds 3, 1 and 2 (each within the scatter of the next, the first and the last beyond it).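

Among these compounds, compound 3 gives the first reading of a single change at this oxygen: with the amino group and the rest of the core held constant, phenyl in place of 2-methoxyethyl gives a 2.2-fold lower number from compound 2 to compound 3 (0.34 log units; beyond the scatter) in this assay and so the group on this oxygen does affect the result, though the step is only modest. The other single change, amino in place of chloro on an aromatic carbon with the phenoxy group kept, gives a 1.9-fold lower number from compound 1 to compound 3 (0.28 log units; within the scatter) and so sets no firm order between those two groups. No measurement here accounts for either step, and the data give no reason for the difference between the phenoxy and 2-methoxyethoxy groups.

The compounds shown leave open how a plain chain without an ether oxygen, such as butyl, or a chain ending in an amine would compare on this oxygen. They also leave open whether a phenyl ring carrying a fluorine or a carboxylic acid would move the number further from that of the unsubstituted phenyl in compound 3.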